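A few compounds are considered here, and "the series" means these few. Any claim that something is new, unique, unknown or untested is made for them only; others in the source may bear on it.

In a functional assay on SK-N-SH cells (Homo sapiens) for inhibition, read by sulforhodamine B assay, with a stated time of 48 h (on this read-out lower numbers stand for stronger inhibition and higher numbers for weaker inhibition), compound 2 `CO[C@@H]1CC=C2NN(c3cncnc3)C(=O)C[C@]2(c2ccccc2)O1` gives 8200 nM, the second highest of the three numbers recorded. Compound 1 `COc1cc(OC)cc(N2NC3=CC[C@@H](OC)O[C@@]3(c3ccncc3)CC2=O)c1` gives 6400 nM, which lies within the scatter of compound 2, while compound 3 `CO[C@@H]1CC=C2NN(c3cncnc3)C(=O)C[C@]2(C)O1` gives 16600 nM, a step of a 2.0-fold higher number from compound 2 to compound 3 (0.31 log units; beyond the scatter) for methyl in place of phenyl on a saturated ring carbon. Compound 4 `CO[C@@H]1CC=C2NN(c3cc(F)cc(Cl)c3)C(=O)C[C@]2(c2ccccc2)O1` carries 3-chloro-5-fluorophenyl in place of pyrimidin-5-yl on an amide-type nitrogen in a ring. Among the compounds with values here, no measured step touches this amide-type nitrogen in a ring: the one measured step alters a different place, and compound 1, which does not carry pyrimidin-5-yl, differs from compound 2 in other places as well. Compound 4 is therefore expected to show a 1.3-fold lower number from compound 2 to compound 4 (0.10 log units; within the scatter), nothing beyond the scatter. The number expected for compound 4 in this assay is 6500 nM, between 2500 nM and 16000 nM.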

Compound 4, half-maximal inhibitory concentration: 17400 nM
Compound 4: middle estimate off by 2.7-fold (0.43 log units), on the low side; the measured number lies above the stated range.
By their numbers in this assay, from the lowest: compounds 1 and 2 (each within the scatter of the next); then compounds 3 and 4 (each within the scatter of the next).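

The amide-type nitrogen in a ring is not indifferent to what it carries: in this assay, 3-chloro-5-fluorophenyl in place of pyrimidin-5-yl gives a 2.1-fold higher number from compound 2 to compound 4 (0.33 log units; beyond the scatter), a modest loss of inhibition. Here the carbon-only aromatic ring with its two halogens reads weaker than the ring with two nitrogens. No measurement on hand explains this step.

The compounds shown do not separate the loss of the ring nitrogens from the arrival of chlorine and fluorine. From the compounds shown here alone, how a plain phenyl, a pyridine ring or a morpholine would read on this nitrogen remains open.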